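The source may hold more compounds than are shown below. What is called first, only, known or untested is meant among the compounds shown, and "the series" means these compounds.

Measured in a functional assay on HepG2 cells (Homo sapiens) for antiproliferative activity, read by MTT assay, with a stated time of 72 h; a higher number here means a weaker inhibitor, a lower number a stronger inhibitor:
Compound 1 `CCN(CC)CCCOc1cc2ncnc(Nc3ccc(C#N)cc3)c2cc1OC`: 59400 nM
Compound 2 `COc1cc2c(Nc3ccc(C#N)cc3)ncnc2cc1OCCCN1CCC(c2ccccc2)CC1`: 4610 nM

Compound 2 holds the lower of these two numbers. Compound 3 `COc1cc2c(Nc3ccc(C#N)cc3)ncnc2cc1OCCCN1CCN(C)CC1` differs from compound 2 in one place: 4-methylpiperazin-1-yl in place of 4-phenylpiperidin-1-yl on a saturated chain carbon, three bonds along the chain from an oxygen on an aromatic ring. There, 4-methylpiperazin-1-yl stands in place of 4-phenylpiperidin-1-yl on a saturated chain carbon, three bonds along the chain from an oxygen on an aromatic ring. For the measured compounds named here, the one measured step that bears on this is large: a 13-fold lower number from compound 1 to compound 2 (1.11 log units; beyond the scatter), with 4-phenylpiperidin-1-yl entering in place of diethylamino. Going by the values given here, compound 3 gives that group up again, so a large move back towards higher numbers is expected in this assay, though no measured compound carries 4-methylpiperazin-1-yl. The expected step is a 6.5-fold higher number from compound 2 to compound 3 (0.81 log units; beyond the scatter). Compound 3 is estimated at 30000 nM, with an expected range of 10000 nM to 80000 nM.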

Compound 3, half-maximal inhibitory concentration: 13800 nM
Beside the measured number, compound 3's estimate is 2.2-fold (0.34 log units) above it; the measured number falls inside the stated range.
By their numbers in this assay, from the lowest: compound 2; then compound 3; then compound 1.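

In this assay, for the compounds shown here, 4-phenylpiperidin-1-yl is not the only group at this place that gives a lower number than diethylamino: 4-methylpiperazin-1-yl does too, with a 4.3-fold lower number from compound 1 to compound 3 (0.63 log units; beyond the scatter). It does not go as far, however, with a 3.0-fold higher number from compound 2 to compound 3 (0.48 log units; beyond the scatter), so the three groups fall into a graded order. Nothing shown here accounts for that order. On these data alone, it remains open whether the difference between compound 2 and compound 3 tracks the phenyl ring or the second ring nitrogen. Plain piperidin-1-yl or morpholin-4-yl at the same place would bear on that.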